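A Chalcone Pair and the Next Bromohydroxy Analogue

The compounds below may be only part of what the source reports. "The series", "measured", "known", "first", "only" and "open" are said of these compounds alone.

Of the compounds shown here, two with a shared core have been tested in a functional assay on HCT-116 cells (Homo sapiens) for antiproliferative activity, read by MTT assay, with a stated time of 24 h; a higher number here means a weaker inhibitor, a lower number a stronger inhibitor. Compound 1, `COc1ccc(C(=O)/C=C/c2cc(OC)c(OC)c(OC)c2)c2c1C=CC(C)(C)O2`, gives 7650 nM in this assay. Compound 2, `COc1ccc(C(=O)/C=C/c2cccc([N+](=O)[O-])c2)c2c1C=CC(C)(C)O2`, gives 8050 nM in this assay. On these two numbers compound 2 stands highest, but its nearest neighbour is compound 1, and the two values lie within the scatter of each other, so no order between them can be claimed.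

The unmeasured compound 3, `COc1ccc(C(=O)/C=C/c2ccc(O)c(Br)c2)c2c1C=CC(C)(C)O2`, keeps the core of compound 2 and differs from it in one place: 3-bromo-4-hydroxyphenyl in place of 3-nitrophenyl on a double-bonded chain carbon bound to a double-bonded chain carbon. Among the compounds with values here, no step between measured compounds is available for this kind of change, so nothing in the numbers so far points in either direction. With both known values close together in this assay, the expectation is that compound 3 will sit near them and that the step of a 1.2-fold lower number from compound 2 to compound 3 (0.06 log units; within the scatter) will be small, likely none beyond the scatter. Compound 3 is therefore estimated at 7000 nM in this assay, with a range from 2500 nM to 20000 nM.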

Compound 3, half-maximal inhibitory concentration: > 10000 nM
Compound 3: a limit, no number; the forecaster's own chance of this, stated with the estimate: 5%; at least 1.4-fold (0.15 log units) between middle value and limit.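

In this assay compound 3 gives > 10000 nM, which is a limit of the assay and not a number. Within the data shown here, this is the first change that can be read as a step, and the exchange of 3-nitrophenyl for 3-bromo-4-hydroxyphenyl on a double-bonded chain carbon bound to a double-bonded chain carbon gives an at least 1.2-fold higher number from compound 2 to compound 3 (0.09 log units; that floor lies within the scatter); the true size of the step remains unknown, and since its floor lies within the scatter, the step alone does not establish that compound 3 is the weaker inhibitor. What it does show is that bringing in a hydrogen-bond donor and a bromine at this place yields no lower number, and that this position can reach the end of the readable range, which only this compound does so far: the limit of > 10000 nM in this assay, at which 1 of the 3 values shown sits.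

The compounds shown leave open whether the bromine or the hydroxyl group goes with this result, since the two enter together. They also leave open whether an amine or a carboxylic acid on the phenyl ring at this place would bring the number down.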